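A few compounds are considered here, and "the series" means these few. Any claim that something is new, unique, unknown or untested is made for them only; others in the source may bear on it.

Measured in a functional assay on A549 cells (Homo sapiens) for inhibition, read by MTT assay, with a stated time of 48 h, tested at 10 uM; a lower number here means less inhibition of growth, a higher number more inhibition of growth at the concentration tested:
compound 1 `O=C(/C=C/c1ccc(OCc2cn(Cc3ccccc3F)nn2)cc1)c1ccc(Br)cc1` gives 38%;
compound 2 `COc1ccc(C(=O)/C=C/c2ccc(OCc3cn(Cc4ccccc4F)nn3)cc2)cc1` gives 21%;
compound 3 `O=C(/C=C/c1ccc(OCc2cn(Cc3cccc(Br)c3)nn2)cc1)c1ccc([N+](=O)[O-])cc1` gives 28%.

Compound 3 lies between the other two numbers, but its gap to compound 2 and its gap to compound 1 both fall within the usual scatter, so no order among the three can be claimed. Compound 4 `O=C(/C=C/c1ccc(OCc2cn(Cc3ccccc3F)nn2)cc1)c1ccc([N+](=O)[O-])cc1` differs from compound 3 by 2-fluorophenyl in place of 3-bromophenyl on a saturated chain carbon bound to an aromatic nitrogen. Going by the values given here, the one measured step, a number 17 percentage points lower from compound 1 to compound 2 (beyond the scatter), changes the ring on the carbonyl, not the benzyl on the triazole, so no measured step bears directly on this change. Among the compounds that already carry the 2-fluorobenzyl, compound 1 gives 38% and compound 2 gives 21%, both near the number for compound 3. In this assay the expected step is a number 2 percentage points higher from compound 3 to compound 4 (within the scatter), not beyond the scatter. Compound 4 is therefore estimated at 30%, with a range from 15% to 45%.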

Compound 4, percent growth inhibition at one concentration: 43%
Compound 4: middle estimate off by 13 percentage points, on the low side; measured number inside the range.
By their numbers in this assay, from the lowest: compounds 2, 3, 1 and 4 (each within the scatter of the next, the first and the last beyond it).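

Going by these compounds alone, the change from 3-bromobenzyl to 2-fluorobenzyl is the first measured change at this place, and in this assay it gives a number 15 percentage points higher from compound 3 to compound 4 (beyond the scatter). With the 2-fluorobenzyl held constant, nitro in place of methoxy gives a number 22 percentage points higher from compound 2 to compound 4 (beyond the scatter), whereas nitro in place of bromo gives a number 5 percentage points higher from compound 1 to compound 4 (within the scatter), so nitro and bromo are not separated here. No measurement explains these steps.

From the compounds shown here alone, the halogen and its ring position change together in compound 3 and compound 4, so their separate contributions remain open. A plain benzyl at this place, or an amine in place of the nitro, would test these results further.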